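Ethyl on the Carbamoyl Nitrogen of Compound 3

The source may hold more compounds than are shown below. What is called first, only, known or untested is meant among the compounds shown, and "the series" means these compounds.

Of the compounds shown here, three sharing one core have been measured in a functional assay on SMMC-7721 cells (Homo sapiens) for cytotoxicity, read by MTT assay, with a stated time of 72 h; on this read-out higher numbers stand for weaker inhibition and lower numbers for stronger inhibition. Compound 1 `CCNC(=O)N1CCN(C(=S)SCc2cn(Cc3ccc(F)cc3)nn2)CC1` gives 44400 nM in this assay. Compound 2 `CCNC(=O)N1CCN(C(=S)SCc2cn(Cc3ccc(Cl)cc3)nn2)CC1` reaches only a limit of the assay, > 128000 nM. Compound 3 `Cc1ccc(Cn2cc(CSC(=S)N3CCN(C(N)=O)CC3)nn2)cc1` likewise reaches only a limit of the assay, > 128000 nM. Among the compounds with values here, the one counted step runs an at least 2.8-fold higher number from compound 1 to compound 2 (0.45 log units; beyond the scatter); it is bounded by the limit of > 128000 nM in this assay, at which 2 of the 3 values shown sit.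

Compound 4 `CCNC(=O)N1CCN(C(=S)SCc2cn(Cc3ccc(C)cc3)nn2)CC1` differs from compound 3 by ethyl in place of hydrogen on an amide-type nitrogen, which read one bond further out is carbamoyl to ethylcarbamoyl. No measured pair differs at this nitrogen, so no shown step bears directly on it; the step from compound 1 to compound 2 concerns the halogen on the aromatic carbon only. Compound 1 carries the ethylcarbamoyl group and gives 44400 nM, so a compound of this kind can register a number in this assay. Compound 3 stands at a limit, so the expected direction is toward a lower number, but the size cannot be drawn from any shown step. The step expected from compound 3 to compound 4 is an at least 1.2-fold lower number from compound 3 to compound 4 (0.10 log units; that floor lies within the scatter). Compound 4 is expected to give 100000 nM in this assay, between 40000 nM and 250000 nM, with a fair chance that only a limit is reported.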

Compound 4, half-maximal inhibitory concentration: > 128000 nM
Compound 4: no number, only a limit; the forecaster's own chance of this, stated with the estimate: 55%; middle value at least 1.2-fold (0.10 log units) from the limit.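

In this assay compound 4 also stands at a limit of the assay, so ethyl on the amide-type nitrogen does not by itself yield a readable number. The steps to compound 4 from compound 2 and from compound 3 cannot be read, as each joins two limits. The one readable step is an at least 2.8-fold higher number from compound 1 to compound 4 (0.45 log units; beyond the scatter), which leaves the fluoro compound as the only one of the ethylcarbamoyl compounds with a number: the limit of > 128000 nM in this assay, at which 3 of the 4 values shown sit.

From the compounds shown here alone, how far carbamoyl to ethylcarbamoyl moves the number on its own remains open, as both compounds of that pair lie at limits. Also open, going by these compounds, is whether a longer chain such as propyl on this nitrogen, or a methoxy group on the aromatic carbon, would give a number in this assay.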